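A few compounds are considered here, and "the series" means these few. Any claim that something is new, unique, unknown or untested is made for them only; others in the source may bear on it.

Measured compounds:

Compound 1, `Cc1ncnc2c1c(-c1cccs1)cn2[C@@H]1O[C@H](CO)[C@@H](O)[C@H]1O`. In a functional assay on K562 cells (Homo sapiens), read by MTT assay, with a stated time of 72 h (a higher number here means a weaker inhibitor, a lower number a stronger inhibitor), compound 1 gives > 20000 nM, which is a limit of the assay rather than a number.

Compound 2, `COc1ncnc2c1c(-c1cccs1)cn2[C@@H]1O[C@H](CO)[C@@H](O)[C@H]1O`. In this assay compound 2 gives 70 nM.

Compound 3, `O=c1[nH]cnc2c1c(-c1cc3ccccc3o1)cn2[C@@H]1O[C@H](CO)[C@@H](O)[C@H]1O`. In this assay compound 3 gives > 20000 nM, again a limit of the assay rather than a number.

Among the measured compounds shown here, compound 2 is therefore the only compound with a real number in this assay; the other two compounds sit at the limit of > 20000 nM in this assay, at which 2 of the 3 values shown sit. For the measured compounds named here, the single measured step, an at least 280-fold lower number from compound 1 to compound 2 (2.45 log units; beyond the scatter), is large, and it changes the group on the shared core, methoxy in place of methyl on an aromatic carbon, while the thiophen-2-yl group is kept.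

Compound 4, `COc1ncnc2c1c(-c1ccco1)cn2[C@@H]1O[C@H](CO)[C@@H](O)[C@H]1O`, keeps the methoxy of compound 2 and differs only by furan-2-yl in place of thiophen-2-yl on an aromatic carbon. Going by the values given here, no measured step touches this position: the one step, from methyl to methoxy, sits on a different carbon, and compound 3, which carries a different five-membered ring, also differs in its other substituent, so it gives no clean comparison. A small ring exchange of this kind is expected to give no step beyond the scatter, so compound 4 is expected to remain close to compound 2. The expected step is a 2.1-fold higher number from compound 2 to compound 4 (0.33 log units; beyond the scatter). The estimate for compound 4 in this assay is 150 nM, with a range from 40 nM to 800 nM.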

Compound 4, half-maximal inhibitory concentration: 60 nM
For compound 4 the middle estimate is 2.5-fold (0.40 log units) above the measured one, within the range that was stated.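

Going from thiophen-2-yl to furan-2-yl gives a 1.2-fold lower number from compound 2 to compound 4 (0.07 log units; within the scatter), so in this assay the group on this aromatic carbon can carry oxygen in place of sulfur in its five-membered ring without a difference beyond the scatter, as long as the methoxy is kept. Among the compounds shown here, the earlier compounds could not show this, as their one readable step lay on a different carbon, and compound 3 differs from the others in two places. Compound 4 also gives the series a second real number, while the other compounds remain at a limit of the assay: the limit of > 20000 nM in this assay, at which 2 of the 4 values shown sit.

On these data alone, two closely matched rings say little about how much this position accepts, so it remains open whether a phenyl ring, an amine or a longer chain on this carbon would keep the number of compound 2. As far as these compounds go, compound 3 carries a different group here but not the methoxy, so the effect of a larger group at this position, with the methoxy in place, also remains open.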